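Ester versus nitrile on the shared core: the next step

The compounds below may be only part of what the source reports. "The series", "measured", "known", "first", "only" and "open" are said of these compounds alone.

Measured so far in an assay on isolated protein for inhibition of Polyunsaturated fatty acid 5-lipoxygenase (Homo sapiens), tested at 10 uM; on this read-out higher numbers stand for more inhibition at the one concentration tested (going by the name of the read-out) and lower numbers for less inhibition:
compound 1 `CCOC(=O)c1c(NC(C)c2ccccc2)[nH]c2ccc(O)cc12` gives 72%
compound 2 `CC(Nc1[nH]c2ccc(O)cc2c1C#N)c1ccccc1` gives 62%

Compound 2 and compound 1 lie within the scatter of each other, so no order between them is claimed. Compound 3 `COC(=O)c1c(NC(C)c2ccccc2)[nH]c2ccc(O)cc12` is not yet measured; it differs from compound 2 by methoxycarbonyl in place of cyano on an aromatic carbon. Going by the values given here, the only measured step that bears on it is a number 10 percentage points lower from compound 1 to compound 2 (within the scatter), which exchanged a related ester for the same nitrile. Going back to an ester, a small step in this assay, if any beyond the scatter, is expected. Compound 3 is estimated at 70%, range 55% to 85%. The expected step is a number 8 percentage points higher from compound 2 to compound 3 (within the scatter).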

Compound 3, a percentage reported as inhibition, at one concentration (the size of the read-out at that concentration, not a potency): 94%
Estimate against measurement, compound 3: 24 percentage points below, outside the stated range (above it).
By their numbers in this assay, from the lowest: compounds 2 and 1 (each within the scatter of the next); then compound 3.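

In this assay, methoxycarbonyl in place of cyano on this aromatic carbon gives a number 32 percentage points higher from compound 2 to compound 3 (beyond the scatter), so exchanging nitrile and ester at this position can matter beyond the scatter, which the ethoxycarbonyl pair did not show. The ester's alkyl end also counts: hydrogen in place of methyl on the saturated chain carbon bound to the oxygen gives a number 22 percentage points higher from compound 1 to compound 3 (beyond the scatter). Nothing at hand explains either step. Open, going by these compounds, is how a carboxylic acid, a primary amide or a propyl ester would read at this position. Also open, on these data alone, is whether the ordering of the esters holds with other groups on the shared core.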